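The compounds below may be only part of what the source reports. "The series", "measured", "known", "first", "only" and "open" are said of these compounds alone.

Compound 1, `CC(C)n1ncc2c(C(=O)NCc3cn(-c4ccccc4)nn3)cccc21`. In a functional assay on MCF7 cells (Homo sapiens) for inhibition, read by MTT assay, with a stated time of 72 h (a higher number here means a weaker inhibitor, a lower number a stronger inhibitor), compound 1 gives > 40000 nM, a limit of the assay.
Compound 2, `CC(C)n1ncc2c(C(=O)NCc3cn(-c4cccc(F)c4)nn3)cccc21`. In this assay compound 2 gives > 40000 nM, a limit of the assay.
Compound 3, `Cc1cccc(-n2cc(CNC(=O)c3cccc4c3cnn4C(C)C)nn2)c1`. In this assay compound 3 gives > 40000 nM, a limit of the assay.

Compound 3 therefore stands only at a limit, and the two other values are limits too, so that (the limit of > 40000 nM in this assay, at which 3 of the 3 values shown sit). Compound 4, `Cc1ccccc1-n1cc(CNC(=O)c2cccc3c2cnn3C(C)C)nn1`, differs from compound 3 by 2-methylphenyl in place of 3-methylphenyl on an aromatic nitrogen. The measured changes on the same phenyl ring, a step that the two limits leave unreadable from compound 1 to compound 3, a step that the two limits leave unreadable from compound 2 to compound 3 and a step that the two limits leave unreadable from compound 1 to compound 2, are all unreadable between the limits, so no direction can be drawn for this assay. The expected result for compound 4 is again a limit, with an estimated 60000 nM (range 20000 nM to 200000 nM). This estimate means a step that the limit leaves unreadable from compound 3 to compound 4, expected to stay within the scatter.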

Compound 4, half-maximal inhibitory concentration: > 40000 nM
Compound 4: only a limit was reported; the forecaster's own chance of this, stated with the estimate: 85%; the middle value is on the limit's open side.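

In this assay compound 4 gives > 40000 nM, a limit of the assay, so its steps from compound 1, compound 2 and compound 3 cannot be read: the limit of > 40000 nM in this assay, at which 4 of the 4 values shown sit.

The compounds shown leave open how far these four compounds differ in strength, and whether any change on this phenyl ring gives a readable value.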